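The source may hold more compounds than are shown below. What is called first, only, known or untested is meant among the compounds shown, and "the series" means these compounds.

Compound 1 `COc1cc(/C=C/C(C)=O)ccc1OCc1cn(-c2ccc(C)cc2)nn1` and compound 2 `COc1cc(/C=C/C(C)=O)ccc1OCc1cn(-c2ccccc2)nn1` share one core and differ only at the outer aromatic ring. In a functional assay on PC-3 cells (Homo sapiens) for antiproliferative activity, read by MTT assay, with a stated time of 48 h (on this read-out higher numbers stand for weaker inhibition and lower numbers for stronger inhibition), compound 1 gives 58100 nM, and compound 2 gives 78600 nM. Going by the values given here, the only change between them, hydrogen in place of methyl on an aromatic carbon, gave a 1.4-fold higher number from compound 1 to compound 2 (0.13 log units; within the scatter). Among the compounds with values here, compound 2 therefore stands at the highest of the two numbers, with compound 1 as its only neighbour, and the two cannot be told apart.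

Compound 3 `COc1cc(/C=C/C(C)=O)ccc1OCc1cn(-c2ccccc2O)nn1` has not yet been measured. It differs from compound 2 by hydroxy in place of hydrogen on an aromatic carbon: a hydroxy group enters on an aromatic carbon of the six-membered aromatic ring of carbon only, ortho to a large group. Within the data shown here, no measured step involves a hydroxy group, so only the methyl-to-hydrogen step above offers any guide, and it stayed within the scatter. On that basis compound 3 is expected to show a 1.1-fold lower number from compound 2 to compound 3 (0.05 log units; within the scatter) in this assay, that is, no step beyond the scatter. The estimate for compound 3 is therefore 70000 nM, with a likely range from 30000 nM to 180000 nM.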

Compound 3, half-maximal inhibitory concentration: 59200 nM
For compound 3 the middle estimate is 1.2-fold (0.07 log units) above the measured one, and the stated range covers the measured number.
By their numbers in this assay, from the lowest: compounds 1, 3 and 2 (each within the scatter of the next).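

In this assay, a hydroxy group entering on an aromatic carbon, ortho to a large group, gives a 1.3-fold lower number from compound 2 to compound 3 (0.12 log units; within the scatter), so adding one hydrogen-bond donor and one hydrogen-bond acceptor at this place produces no step beyond the scatter. Exchanging the whole outer group on the aromatic nitrogen, with 2-hydroxyphenyl in place of 4-methylphenyl, gives a 1.0-fold higher number from compound 1 to compound 3 (0.01 log units; within the scatter), so these two groups cannot be told apart in this read-out, and a methyl group and a hydroxy group, each tried on this outer ring, leave the number within the scatter. Nothing available offers an explanation for this flat result.

The compounds shown leave open whether a different kind of group at this place, such as an amine or a carboxylic acid, would produce a step beyond the scatter. Going by these compounds alone, they also leave open whether a hydroxy group elsewhere on this ring would behave as it does here, since every step so far remains within the scatter and none yet shows what this outer ring can change.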